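This account rests on a few compounds, and the source may have more. Where it says the series, first, only, none or still open, it means among the compounds named here.

Series notes, arylidene variation on a shared core.

Compound 1 `COc1ccc(/C=N/NC(=O)CSc2nnc(-c3ccncc3)n2-c2ccccc2)cc1` gives 27100 nM in a functional assay on HepG2 cells (Homo sapiens) for inhibition, read by MTT assay, with a stated time of 48 h; on this read-out lower numbers stand for stronger inhibition and higher numbers for weaker inhibition. Compound 2 `O=C(CSc1nnc(-c2ccncc2)n1-c1ccccc1)N/N=C/c1ccc([N+](=O)[O-])cc1` gives 15900 nM in this assay, and compound 3 `O=C(CSc1nnc(-c2ccncc2)n1-c1ccccc1)N/N=C/c1ccccc1F` gives 15200 nM in this assay. Compound 3 holds the smallest of the three numbers, but the steps that lead to it, a 1.8-fold lower number from compound 1 to compound 3 (0.25 log units; within the scatter) and a 1.0-fold lower number from compound 2 to compound 3 (0.02 log units; within the scatter), are both within the scatter, as is a 1.7-fold lower number from compound 1 to compound 2 (0.23 log units; within the scatter). So far no change of the aryl group on the carbon with a double bond to nitrogen has moved the number beyond the scatter.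

Compound 4 `O=C(CSc1nnc(-c2ccncc2)n1-c1ccccc1)N/N=C/c1ccc(O)c(O)c1` carries the next change at the same place: 3,4-dihydroxyphenyl in place of 2-fluorophenyl on a carbon with a double bond to nitrogen. All three measured steps bear on it, since each also swaps the aryl group on the carbon double-bonded to nitrogen, and none of them rose above the scatter. The expectation is therefore no step beyond the scatter in this assay. The step expected in this assay is a 1.0-fold lower number from compound 3 to compound 4 (0.01 log units; within the scatter). Compound 4 is thus expected to give about 15000 nM in this assay, with a range from 5000 nM to 45000 nM.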

Compound 4, half-maximal inhibitory concentration: 16900 nM
Beside the measured number, compound 4's estimate is 1.1-fold (0.05 log units) below it; measured number inside the range.
By their numbers in this assay, from the lowest: compounds 3, 2, 4 and 1 (each within the scatter of the next).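

The entering 3,4-dihydroxyphenyl brings 2 hydrogen-bond donors and 2 hydrogen-bond acceptors to a place where the leaving 2-fluorophenyl has none, yet in this assay the three new steps, a 1.1-fold higher number from compound 3 to compound 4 (0.05 log units; within the scatter) and a 1.1-fold higher number from compound 2 to compound 4 (0.03 log units; within the scatter) and also a 1.6-fold lower number from compound 1 to compound 4 (0.21 log units; within the scatter), all lie within the scatter. The flat picture at the carbon with a double bond to nitrogen therefore now extends to an aryl group carrying two hydroxyl groups, and compounds 1 to 4 all stand within the scatter of one another. No supporting measurement bears on why these numbers stay together.

Open, on these data alone, is whether an aryl group bearing a dimethylamino group or a carboxylic acid would give a step beyond the scatter at this place. Also open, as far as these compounds go, is what a longer chain in place of the aryl group, or a change elsewhere on the shared core, would do to the number.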